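Phenoxyphenyl Quinolinones: Removing Trifluoromethoxy, Cytotoxicity Read-Out

The source may hold more compounds than are shown below. What is called first, only, known or untested is meant among the compounds shown, and "the series" means these compounds.

Measured so far:
Compound 1 `COc1cc2[nH]c(C)c(-c3ccc(Oc4ccc(F)cc4)cc3)c(=O)c2cc1Cl` gives in an ADME assay on HepG2 cells (Homo sapiens) for cytotoxicity, read by resazurin assay, with a stated time of 24 h (a higher number here means a weaker inhibitor, a lower number a stronger inhibitor), a value of > 10000 nM, which is a limit of the assay and not a number.
Compound 2 `COc1cc2[nH]c(C)c(-c3ccc(Oc4ccc(OC(F)(F)F)cc4)cc3)c(=O)c2cc1F` gives in this assay a value of > 10000 nM, again only a limit.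
Compound 3 `COc1cc2[nH]c(C)c(-c3ccc(Oc4ccc(F)c(OC(F)(F)F)c4)cc3)c(=O)c2cc1Cl` gives in this assay a value of > 10000 nM, also a limit.

From compound 3 to compound 1 the change is hydrogen in place of trifluoromethoxy on an aromatic carbon. The resulting step that the two limits leave unreadable from compound 3 to compound 1 cannot be sized, because of the limit of > 10000 nM in this assay, at which 3 of the 3 values shown sit.

Compound 4 `COc1cc2[nH]c(C)c(-c3ccc(Oc4ccccc4)cc3)c(=O)c2cc1F` has not yet been measured; it differs from compound 2 by hydrogen in place of trifluoromethoxy on an aromatic carbon. This is the same kind of change as the earlier one, though the surroundings differ: in compound 3 the leaving group sits ortho to a fluoro group and meta to a large group, whereas in compound 2 it sits para to a large group. How the cores of compound 2 and compound 3 differ is not broken down here.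

For compound 4 the step that the limit leaves unreadable from compound 2 to compound 4 is expected to be small, resting on a step that the two limits leave unreadable from compound 3 to compound 1 and on (the limit of > 10000 nM in this assay, at which 3 of the 3 values shown sit). Compound 4 is therefore estimated at 20000 nM, between 8000 nM and 60000 nM, most likely reported again only as a limit.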

Compound 4, half-maximal inhibitory concentration: > 10000 nM
Compound 4 gave a limit, no number (the forecaster's own chance of this, stated with the estimate: 85%); the middle value is on the limit's open side.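

For compound 2 and compound 4, no size can be given to the change from 4-(trifluoromethoxy)phenyl to phenyl, so no new step can be read: the limit of > 10000 nM in this assay, at which 4 of the 4 values shown sit.

The compounds shown leave open where any of them would reach half-maximal inhibition in this assay, and whether replacing trifluoromethoxy with hydrogen shifts that value at all.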